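A few compounds are considered here, and "the series" means these few. Any claim that something is new, unique, unknown or untested is made for them only; others in the source may bear on it.

In an ADME assay on HEp-2 cells (Homo sapiens) for cytotoxicity (on this read-out higher numbers stand for lower toxicity in this test and lower numbers for higher toxicity in this test), compound 1 (`CNCc1ccc2c(c1)nc(Cn1c(=O)n(C(C)C)c3ccccc31)n2CCC(C)C`) gives 1480 nM, while compound 2 (`CC(C)CCn1c(Cn2c(=O)n(C(C)C)c3ccccc32)nc2cc(CO)ccc21`) gives 31600 nM, the higher of the two numbers. Going by the values given here, the one measured step between them is a 21-fold higher number from compound 1 to compound 2 (1.33 log units; beyond the scatter), with hydroxy in place of methylamino on a saturated chain carbon bound to an aromatic carbon.

Compound 3 (`CCc1ccc2c(c1)nc(Cn1c(=O)n(C(C)C)c3ccccc31)n2CCC(C)C`) departs from compound 2 at that same place: methyl in place of hydroxy on a saturated chain carbon bound to an aromatic carbon. In words, this is methyl in place of hydroxy on a saturated chain carbon bound to an aromatic carbon, or, cut one bond further out, hydroxymethyl to ethyl.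

Among the compounds with values here, no measured pair makes this exact exchange, so the evidence is indirect. The step of a 21-fold higher number from compound 1 to compound 2 (1.33 log units; beyond the scatter) shows that a change at this place can move the number in this assay by a large amount, but compound 3 carries no methylamino group, so a change of that size is not expected here. A small move to a lower number is expected instead, close to the edge of the usual scatter. The expected change is a 2.3-fold lower number from compound 2 to compound 3 (0.35 log units; beyond the scatter). For compound 3 the estimated value is 14000 nM, with an expected range from 3500 nM to 50000 nM.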

Compound 3, half-maximal cytotoxic concentration: 18500 nM
Estimate against measurement, compound 3: 1.3-fold (0.12 log units) below, and the stated range covers the measured number.
By their numbers in this assay, from the lowest: compound 1; then compounds 3 and 2 (each within the scatter of the next).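

In this assay the step of a 1.7-fold lower number from compound 2 to compound 3 (0.23 log units; within the scatter) leaves hydroxy and methyl on this saturated chain carbon bound to an aromatic carbon not separable, so losing the hydrogen-bond donor and acceptor counted for hydroxy brings no change that can be read here. The earlier comparison could not show whether the gap between compound 1 and compound 2 was tied to methylamino or to hydroxy, but the step of a 13-fold higher number from compound 1 to compound 3 (1.10 log units; beyond the scatter) is large, as is the step of a 21-fold higher number from compound 1 to compound 2 (1.33 log units; beyond the scatter), and so compound 1, the only one of the three with methylamino, stands apart from both compounds without it. Nothing available explains why methylamino differs from the other two groups at this place.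

The compounds shown leave open whether the lower number belongs to methylamino alone or would also appear with another amine at this place, such as aminomethyl or dimethylaminomethyl. They also leave open how a carboxylic acid or a longer chain at the same place would read in this assay and whether the close agreement of hydroxy and methyl would extend to such groups.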